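Chain unsaturation in a resorcinol-type cytotoxicity series

The source may hold more compounds than are shown below. What is called first, only, known or untested is meant among the compounds shown, and "the series" means these compounds.

Compound 1 `C=C1CC[C@H]2C(C)(C)CCC[C@]2(C)[C@H]1CC/C(C)=C/COc1cc(O)c2c(=O)c(O)c(-c3ccc(O)cc3)oc2c1` gives > 100000 nM in a functional assay on HT-29 cells (Homo sapiens) for cytotoxicity, read by XTT assay, with a stated time of 72 h; a higher number here means a weaker inhibitor, a lower number a stronger inhibitor; this value is an assay limit, not a number.
Compound 2 `CCCCCCCCCCCCCCCCCCOc1cc(O)c(C(C)=O)c(O)c1` gives > 100000 nM in this assay; this too is a limit only.

Going by the values given here, compound 2 therefore stands at the top of what the assay resolves, since the limit of > 100000 nM in this assay, at which 2 of the 2 values shown sit: both values shown are limits and no measured step between compounds exists. Compound 3 `CCCCCCCC/C=C\CCCCCCCCOc1cc(O)c(C(C)=O)c(O)c1` differs from compound 2 by dec-1-en-1-yl in place of decyl on a saturated chain carbon, eight bonds along the chain from an oxygen on an aromatic ring. For this change no step beyond the scatter is expected in this assay, in either direction. Compound 3 is expected at 100000 nM, within 40000 nM to 250000 nM, which amounts to a number no higher from compound 2 to compound 3 (the limit leaves the size open).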

Compound 3, half-maximal inhibitory concentration: 31000 nM
For compound 3 the middle estimate is 3.2-fold (0.51 log units) above the measured one, outside the stated range (below it).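

Dec-1-en-1-yl in place of decyl at this chain position gives an at least 3.2-fold lower number from compound 2 to compound 3 (0.50 log units; beyond the scatter) in this assay. Going by these compounds alone, a single double bond outside aromatic rings, with no change in the count of chain carbons, is thus enough for a step beyond the scatter, and compound 3 gives the only value shown that is not a limit. Compound 2 gives only a limit, so the size of the step stays open: the limit of > 100000 nM in this assay, at which 2 of the 3 values shown sit.

Going by these compounds, whether a shorter chain with a double bond, or an amine on the chain, would keep this step remains open.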